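Mirror-Image Pairs in a Lysosomal Alpha-Glucosidase Series

This account rests on a few compounds, and the source may have more. Where it says the series, first, only, none or still open, it means among the compounds named here.

Measured compounds:
- compound 1, `COc1ccc([C@@]2(CO)NC[C@H](O)[C@H]2O)cc1`, gives 2100 nM
- compound 2, `COc1ccc([C@]2(CO)NC[C@@H](O)[C@@H]2O)cc1OC`, gives 105000 nM

Of the compounds shown here, two have been measured in an assay on isolated protein for inhibition of lysosomal alpha-glucosidase (Rattus norvegicus), read by colorimetric assay; a lower number here means a stronger inhibitor, a higher number a weaker inhibitor. Compound 2 stands at the top of these two numbers: compound 1 lies far lower, and that gap is well beyond the usual scatter. Compound 3, `COc1ccc([C@@]2(CO)NC[C@H](O)[C@H]2O)cc1OC`, is the next compound to be measured in this assay. Relative to compound 2, compound 3 shows the following: the two compounds have the same atoms and bonds and differ only in configuration as drawn: 3 of 3 stereo elements differ (all stereocentres are inverted: mirror images); a stereocentre at a saturated ring carbon is drawn R in compound 2 and S in compound 3; a stereocentre at a saturated ring carbon is drawn R in compound 2 and S in compound 3; a stereocentre at a saturated ring carbon is drawn R in compound 2 and S in compound 3. Compound 3 is therefore the mirror image of compound 2, and it shares the drawn configuration of compound 1 at every ring stereocentre. Given that compound 1 gives 2100 nM in the same configuration, a large downward step from compound 2 to compound 3 is expected, a 35-fold lower number from compound 2 to compound 3 (1.54 log units; beyond the scatter). Compound 3 is estimated at 3000 nM, with a plausible range from 1000 nM to 10000 nM.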

Compound 3, half-maximal inhibitory concentration: 60000 nM
Compound 3: the middle estimate sits 20-fold (1.30 log units) below what was measured, and the stated range ends below it.
By their numbers in this assay, from the lowest: compound 1; then compounds 3 and 2 (each within the scatter of the next).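

In this assay, going by these compounds alone, the mirror-image pair gives the first direct reading of configuration, and the step is small (a 1.8-fold lower number from compound 2 to compound 3 (0.24 log units; within the scatter)). Within the data shown here, with the second methoxy group present, inverting all three stereocentres therefore does not separate the two compounds in this assay, and configuration is the only variable in this comparison: the fact that compounds 2 and 3 differ only in the configuration as drawn. Among these compounds, the first single-place comparison with the configuration held constant shows that methoxy in place of hydrogen on an aromatic carbon accounts for a large step (a 29-fold higher number from compound 1 to compound 3 (1.46 log units; beyond the scatter)), so the wide gap between compound 1 and compound 2 tracks this substitution rather than the inversion.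

It remains open whether the mirror image of compound 1 would likewise match compound 1, since the pair shown carries the added methoxy group. Going by these compounds, it is also open whether a hydroxyl group or a fluorine atom at that place would give a step of similar size.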